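This account rests on a few compounds, and the source may have more. Where it says the series, first, only, none or still open, it means among the compounds named here.

In a functional assay on U-251 cells (Homo sapiens) for inhibition, read by sulforhodamine B assay, with a stated time of 48 h (a higher number here means a weaker inhibitor of growth, a lower number a stronger inhibitor of growth), compound 1 `COc1ccc(/C=C/C2(C)C=CC(=O)O2)c(OC)c1` gives 62800 nM and compound 2 `COc1ccc(/C=C/C2(C)C=CC(=O)O2)c(OC)c1OC` gives 87200 nM. Compound 1 has the lower of only these two numbers, but they lie within the scatter of each other, so the pair cannot be ranked. Compound 3 `COc1cc(OC)c(/C=C/C2(C)C=CC(=O)O2)c(OC)c1` keeps the core of compound 1 and carries a single change: methoxy in place of hydrogen on an aromatic carbon. Within the data shown here, the one measured step that bears on this is the same swap made at a different place on the ring, a 1.4-fold higher number from compound 1 to compound 2 (0.14 log units; within the scatter), so no shift beyond the scatter is expected for compound 3. A single step is thin evidence, and the new place has not been tested. The expected result is a 1.3-fold higher number from compound 1 to compound 3 (0.11 log units; within the scatter). For compound 3 the estimate is 80000 nM, with an expected range from 45000 nM to 140000 nM.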

Compound 3, concentration for total growth inhibition: 193000 nM
Compound 3: middle estimate off by 2.4-fold (0.38 log units), on the low side; measured number above the stated range.
By their numbers in this assay, from the lowest: compounds 1 and 2 (each within the scatter of the next); then compound 3.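

In this assay, methoxy in place of hydrogen on the aromatic carbon ortho to a group of 9 heavy atoms and meta to two methoxy groups gives a 3.1-fold higher number from compound 1 to compound 3 (0.49 log units; beyond the scatter), a modest shift towards weaker growth inhibition. The same swap at another place on the ring gave only a 1.4-fold higher number from compound 1 to compound 2 (0.14 log units; within the scatter), so within these three compounds the place of the added methoxy matters, which the first pair alone could not show. Nothing available here explains this difference between the two places.

As far as these compounds go, it remains open whether the shift belongs to methoxy itself or would appear with any group at this place. A hydroxyl or a fluorine atom there could separate these two readings, and an amine would show whether a different kind of group follows the same trend.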